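Swapping a Bromo Group for Trifluoromethoxy on a Stilbene Chromone

The source may hold more compounds than are shown below. What is called first, only, known or untested is meant among the compounds shown, and "the series" means these compounds.

Of the compounds shown here, two sharing one core have been tested in a functional assay on A549 cells (Homo sapiens) for antiproliferative activity, read by MTT assay, with a stated time of 12 h; a lower number here means a stronger inhibitor, a higher number a weaker inhibitor. Compound 1 `COc1cc(OC)c2c(=O)cc(/C=C/c3ccc(OCC4CC4)cc3)oc2c1` carries a cyclopropylmethoxy group and gives 20900 nM. Compound 2 `COc1cc(OC)c2c(=O)cc(/C=C/c3ccc(Br)cc3)oc2c1`, in which bromo replaces that group, reaches only a limit of the assay in this assay, > 40000 nM. So compound 2 stands at the upper edge of what can be reported, as the limit of > 40000 nM in this assay, at which 1 of the 2 values shown sits, shows, and the measured step is an at least 1.9-fold higher number from compound 1 to compound 2 (0.28 log units; that floor lies within the scatter).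

Compound 3 `COc1cc(OC)c2c(=O)cc(/C=C/c3ccc(OC(F)(F)F)cc3)oc2c1` is not yet measured. It differs from compound 2 by trifluoromethoxy in place of bromo on an aromatic carbon. For the measured compounds named here, no measured step replaces bromo with trifluoromethoxy; the only step on record, from an oxygen-linked group to bromo, raised the number at least modestly. The new change again puts an oxygen-linked group where bromo was, so for this assay the expected move is an at least 1.3-fold lower number from compound 2 to compound 3 (0.12 log units; that floor lies within the scatter), a return toward the range of compound 1 rather than any strong inhibition. Compound 3 is therefore estimated at 30000 nM, with a range from 10000 nM to 90000 nM.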

Compound 3, half-maximal inhibitory concentration: 24200 nM
Compound 3: the middle estimate sits 1.2-fold (0.09 log units) above what was measured; the range from low to high includes it.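

Compound 2 gives only a limit of the assay, not a number: the limit of > 40000 nM in this assay, at which 1 of the 3 values shown sits. Read against that limit, the change from bromo to trifluoromethoxy is an at least 1.6-fold lower number from compound 2 to compound 3 (0.21 log units; that floor lies within the scatter), so this step alone does not separate the two groups. The new information lies in the comparison of the two oxygen-linked groups at this position. Trifluoromethoxy and cyclopropylmethoxy cannot be told apart in this assay, with a 1.2-fold higher number from compound 1 to compound 3 (0.06 log units; within the scatter), even though the cyclopropylmethoxy group carries a ring and the trifluoromethoxy group carries three fluorine atoms and no ring.

On these data alone, how an amine, a carboxylic acid or a longer alkoxy chain on this aromatic carbon would read remains open, and so does whether the oxygen link itself matters, since a group joined through carbon would be needed to test that. Also open, as far as these compounds go, is whether any group here can bring the number far below that of compound 1, or whether changes elsewhere on the shared core would be needed for stronger inhibition.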